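Chloro Added to a Shared Core: Expecting Compound 4

This account rests on a few compounds, and the source may have more. Where it says the series, first, only, none or still open, it means among the compounds named here.

Compound 1 `Cc1ccc(N2CCN(CCCOc3ccc4c(=O)cc(-c5ccccc5)oc4c3)CC2)cc1` and compound 2 `Cc1ccc(N2CCN(CCCOc3ccc4c(=O)cc(-c5ccc(Cl)cc5)oc4c3)CC2)cc1` differ by one change, (chloro in place of hydrogen on an aromatic carbon). In a functional assay for antagonist activity at Adrenergic receptor alpha-1 (Rattus norvegicus) (a higher number here means weaker binding, a lower number tighter binding), compound 1 gives 20.7 nM, and compound 2 gives 8.17 nM, so the change produced a 2.5-fold lower number from compound 1 to compound 2 (0.40 log units; beyond the scatter). Compound 3 `O=c1cc(-c2ccccc2)oc2cc(OCCCBr)ccc12` shares part of its structure with compound 1, but the difference between the two cores is not broken down here; in this assay compound 3 gives 390 nM, the highest of the three numbers. Compound 4 `O=c1cc(-c2ccc(Cl)cc2)oc2cc(OCCCBr)ccc12` is compound 3 carrying the same change, (chloro in place of hydrogen on an aromatic carbon), at a place described in identical words, so it is the same change. Because the earlier step was a 2.5-fold lower number from compound 1 to compound 2 (0.40 log units; beyond the scatter), the step to compound 4 is expected to be a 2.3-fold lower number from compound 3 to compound 4 (0.36 log units; beyond the scatter). Compound 4 is therefore estimated at 170 nM, likely between 70 nM and 400 nM.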

Compound 4, dissociation constant: 679 nM
Beside the measured number, compound 4's estimate is 4.0-fold (0.60 log units) below it; the whole stated range lies below it.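

Placed on the core of compound 3, the chloro gives a 1.7-fold higher number from compound 3 to compound 4 (0.24 log units; within the scatter) in this assay so this pair cannot be told apart. The same change therefore did not behave alike on the two cores: the same change on two cores in this assay, a 2.5-fold lower number (0.40 log units; beyond the scatter) from compound 1 to compound 2 and a 1.7-fold higher number (0.24 log units; within the scatter) from compound 3 to compound 4, 4.4-fold (0.64 log units) apart, beyond the scatter of two such steps. This shows that the lower number seen on the core of compound 1 cannot simply be assumed on another core in this series, but it does not show why the cores differ, and two pairs set no general rule.

The compounds shown leave open whether a fluoro or a methoxy group in place of the chloro would also differ between these two cores.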